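Replacing 3-fluorophenyl with 4-methylphenyl on the shared core

A few compounds are considered here, and "the series" means these few. Any claim that something is new, unique, unknown or untested is made for them only; others in the source may bear on it.

In a functional assay on SGC-7901 cells (Homo sapiens) for antiproliferative activity, read by MTT assay, with a stated time of 72 h (on this read-out lower numbers stand for stronger inhibition and higher numbers for weaker inhibition), compound 1 (`COc1cc(-n2cnc3ccc(-c4cccc(O)c4)cc32)cc(OC)c1OC`) gives 53 nM, and compound 2 (`COc1cc(-n2cnc3ccc(-c4cccc(F)c4)cc32)cc(OC)c1OC`) gives 2490 nM, the higher of the two numbers. Compound 3 (`COc1cc(-n2cnc3ccc(-c4ccc(C)cc4)cc32)cc(OC)c1OC`) is not yet measured; it differs from compound 2 as follows: 4-methylphenyl in place of 3-fluorophenyl on an aromatic carbon. Among the measured compounds shown here, the only measured step, a 47-fold higher number from compound 1 to compound 2 (1.67 log units; beyond the scatter), was large, but it put fluoro in place of hydroxy, and compound 3 carries no hydroxy either. No step beyond the scatter is therefore expected, and the estimated change is a 1.7-fold lower number from compound 2 to compound 3 (0.22 log units; within the scatter). For compound 3 the expected value is 1500 nM, within an estimated range of 250 nM to 8000 nM.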

Compound 3, half-maximal inhibitory concentration: 200 nM
Compound 3: the middle estimate sits 7.5-fold (0.88 log units) above what was measured; measured number outside the range, below it.
By their numbers in this assay, from the lowest: compound 1; then compound 3; then compound 2.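

In this assay, compound 2 gives a weak number, and compound 3 carries no hydroxy either. Even so, 4-methylphenyl in place of 3-fluorophenyl gives a large improvement (a 12-fold lower number from compound 2 to compound 3 (1.10 log units; beyond the scatter)). The 3-hydroxyphenyl group still keeps a modest edge (a 3.8-fold higher number from compound 1 to compound 3 (0.58 log units; beyond the scatter)), so most of the gap closes, but not all of it. Nothing available explains either step.

Going by these compounds, whether the gain belongs to the methyl or to its place on the ring stays open, as the swap alters both. A 3-methylphenyl or 4-fluorophenyl group would separate the two, and a 3-aminophenyl group would show whether an amine can stand in for the hydroxy.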